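This account rests on a few compounds, and the source may have more. Where it says the series, first, only, none or still open, it means among the compounds named here.

Measured compounds in a functional assay on MDA-MB-436 cells (Homo sapiens) for antiproliferative activity, read by MTT assay, with a stated time of 48 h; a higher number here means a weaker inhibitor, a lower number a stronger inhibitor:
compound 1 `C=CS(=O)(=O)N1CCN(c2ncnc3sc(-c4ccccc4)cc23)CC1`: 21100 nM
compound 2 `C=CS(=O)(=O)N1CCN(c2ncnc3sc(-c4ccc(OC)cc4)cc23)CC1`: 28400 nM
compound 3 `CCCNC(=O)N1CCN(c2ncnc3sc(-c4ccc(N5CCN(C)CC5)cc4)cc23)CC1`: 12400 nM

Compound 3 has the lowest of the three numbers in this assay. Its gap to compound 1 stays within the scatter, while its gap to compound 2 lies beyond it, so only the comparison with compound 2 can be read as a real difference. Going by the values given here, the one single-point step among the measured compounds, a 1.3-fold higher number from compound 1 to compound 2 (0.13 log units; within the scatter), concerns a methoxy in place of hydrogen on an aromatic carbon and is within the scatter; it says nothing about the urea end of the molecule.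

Compound 4, `CN1CCN(c2ccc(-c3cc4c(N5CCN(C(=O)Nc6cc(C(F)(F)F)ccc6F)CC5)ncnc4s3)cc2)CC1`, differs from compound 3 at that urea end: 2-fluoro-5-(trifluoromethyl)phenyl in place of propyl on an amide-type nitrogen. Among the compounds with values here, no measured pair varies this position, so there is no step to lean on; the expectation rests on the unchanged remainder of compound 3 and on the size of the group that enters. A moderate move toward a lower number is expected, a 2.1-fold lower number from compound 3 to compound 4 (0.32 log units; beyond the scatter), but with wide uncertainty given the absence of any bearing step. Compound 4 is therefore estimated at 6000 nM in this assay, in a range from 1500 nM to 25000 nM.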

Compound 4, half-maximal inhibitory concentration: 8840 nM
Compound 4: the middle estimate sits 1.5-fold (0.17 log units) below what was measured; the range from low to high includes it.
By their numbers in this assay, from the lowest: compounds 4, 3, 1 and 2 (each within the scatter of the next, the first and the last beyond it).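

In this assay the exchange of propyl for 2-fluoro-5-(trifluoromethyl)phenyl on the amide-type nitrogen gives a 1.4-fold lower number from compound 3 to compound 4 (0.15 log units; within the scatter) and therefore no readable difference at this position. Going by these compounds alone, this is the only step that varies this position, and it shows that a large change in the group, from 3 heavy atoms in an open chain to 11 heavy atoms with a six-membered aromatic ring and fluorine, leaves compound 3 and compound 4 indistinguishable in this read-out. No measurement in hand offers an explanation for this outcome.

Because the two groups differ in several features at once, this single step cannot separate the contribution of the ring from those of the fluoro and trifluoromethyl substituents, and an unsubstituted phenyl would be needed to make that distinction. Also open, on these data alone, is whether a longer alkyl chain, a chain ending in an amine or one ending in a carboxylic acid on the same nitrogen would move the number beyond the scatter from compound 3.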